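Swapping a methoxy for a methylamino on a kinase inhibitor

The source may report more compounds than this note shows. Statements on the series, on what has been measured and on what is new or still open speak of the compounds shown alone.

Of the compounds shown here, three share one core and have been measured in an assay on isolated protein for inhibition of high affinity nerve growth factor receptor (Homo sapiens), read by 33P incorporation; a lower number here means a stronger inhibitor, a higher number a weaker inhibitor. Compound 1 `Nc1cc(NS(=O)(=O)c2ccc(F)cc2F)cc(-c2cnc3[nH]cc(-c4ccncc4)c3c2)c1` gives 2.97 nM. Compound 2 `Nc1cccc(-c2cnc3[nH]cc(-c4ccncc4)c3c2)c1` gives 42.7 nM. Compound 3 `COc1cccc(-c2cnc3[nH]cc(-c4ccncc4)c3c2)c1` gives 22.7 nM, the second highest of the three numbers; its nearest neighbour is compound 2, while compound 1 gives a number that is lower beyond the scatter. Compound 4 `CNc1cccc(-c2cnc3[nH]cc(-c4ccncc4)c3c2)c1` has not yet been measured; it differs from compound 3 in one place: methylamino in place of methoxy on an aromatic carbon. For the measured compounds named here, the only measured step that touches this spot is the one a 1.9-fold lower number from compound 2 to compound 3 (0.27 log units; within the scatter), where an amino became a methoxy. That step stayed within the scatter, so there is no sign yet that changing a small group at this position moves the number much. For compound 4, whose methylamino sits between the amino of compound 2 and the methoxy of compound 3 in kind, the expected step is a 1.3-fold higher number from compound 3 to compound 4 (0.12 log units; within the scatter). Compound 4 is therefore estimated at 30 nM, with a likely range from 10 nM to 90 nM.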

Compound 4, half-maximal inhibitory concentration: 31.4 nM
Compound 4: middle estimate off by 1.0-fold (0.02 log units), on the low side, within the range that was stated.
By their numbers in this assay, from the lowest: compound 1; then compounds 3, 4 and 2 (each within the scatter of the next).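

In this assay, putting methylamino in place of methoxy gives a 1.4-fold higher number from compound 3 to compound 4 (0.14 log units; within the scatter) and putting a methyl in place of the hydrogen on the nitrogen of compound 2 gives a 1.4-fold lower number from compound 2 to compound 4 (0.13 log units; within the scatter) on the same scale. Compound 4 thus joins compound 2 and compound 3 in a set whose members all lie within the scatter of one another, so amino, methylamino and methoxy cannot be told apart here, even though the methylamino brings a hydrogen-bond donor that the methoxy lacks. No measurement is available that would explain this result.

All three groups are small, so a carboxylic acid or a longer chain ending in an amine could behave quite differently at this spot. A bare hydrogen here also remains an open comparison.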